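Removing one purine chloro from a chloromethylbenzyl cytotoxic agent

The source may report more compounds than this note shows. Statements on the series, on what has been measured and on what is new or still open speak of the compounds shown alone.

Compound 1, `ClCc1ccc(Cn2cnc3nc(Cl)nc(Cl)c32)cc1`: 1900 nM
Compound 2, `ClCc1ccccc1Cn1cnc2ncnc(Cl)c21`: 3980 nM

Of the compounds shown here, two have been tested in a functional assay on 786-0 cells (Homo sapiens) for cytotoxicity, read by sulforhodamine B assay, with a stated time of 48 h; a higher number here means a weaker inhibitor of growth, a lower number a stronger inhibitor of growth. Compound 1 gives 1900 nM, the lower of the two numbers, and so the stronger growth inhibitor. Compound 2, which carries its chloromethyl group on a different position of the benzyl ring and lacks one of the purine chloro groups, gives 3980 nM; the gap to compound 1 lies beyond the usual scatter.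

Compound 3, `ClCc1ccc(Cn2cnc3ncnc(Cl)c32)cc1`, keeps the benzyl part of compound 1 and differs only on the shared core: hydrogen in place of chloro on an aromatic carbon. Going by the values given here, no directly comparable pair of measured compounds shows this change alone, so any expectation rests on the core that compound 3 shares with compound 2, which gives 3980 nM. A modest loss of potency is therefore expected, so that the step of a 1.6-fold higher number from compound 1 to compound 3 (0.20 log units; within the scatter) is estimated to be small and upward. Compound 3 is expected to give about 3000 nM, within a range of 1200 nM to 8000 nM.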

Compound 3, concentration for 50% growth inhibition: 1690 nM
The estimate for compound 3 lay 1.8-fold (0.25 log units) above the measured number; low and high end bracket the measured number.
By their numbers in this assay, from the lowest: compounds 3 and 1 (each within the scatter of the next); then compound 2.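

Replacing chloro with hydrogen on this aromatic carbon, between two ring nitrogen atoms, gives a 1.1-fold lower number from compound 1 to compound 3 (0.05 log units; within the scatter). Going by these compounds alone, this is the first reading of that change alone, with the benzyl part held constant. In this assay the two compounds cannot be told apart, so with this benzyl part, growth inhibition at the level of compound 1 does not require this chloro, and the remaining chloro and the chloromethyl group are still present in compound 3.

Within the data shown here, an amine or a methoxy group at this position could show whether the carbon tolerates larger replacements or only this swap, and the same swap with the chloromethyl group elsewhere on the benzyl ring also remains open. Nothing available here explains why removing this chloro leaves the number within the scatter.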